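A methyl in place of hydrogen on compound 2

The compounds below may be only part of what the source reports. "The series", "measured", "known", "first", "only" and "open" are said of these compounds alone.

Compound 1 `CCNCC1CCN(c2c(F)cc3c(=O)c(C(=O)O)cn(C4CC4)c3c2Cl)C1`: 11 ug/mL; 11 ug/mL; < 11 ug/mL (3 entries)
Compound 2 `O=C(O)c1cn(C2CC2)c2c(Cl)c(N3CCNCC3)c(F)cc2c1=O`: 43 ug/mL

Both compounds were tested in a functional assay on V79 cells (Cricetulus griseus) for cytotoxicity, read by colony formation; on this read-out higher numbers stand for weaker inhibition and lower numbers for stronger inhibition. Going by the values given here, compound 2 stands at 43 ug/mL, the only single number available. Compound 1 has several entries, (the several entries of compound 1 in this assay, 11 ug/mL; 11 ug/mL; < 11 ug/mL (3 entries)), and one of these is a limit, so it offers no single number.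

Compound 3 `CC1CN(c2c(F)cc3c(=O)c(C(=O)O)cn(C4CC4)c3c2Cl)CCN1` differs from compound 2 by methyl in place of hydrogen on a saturated ring carbon, (methyl in place of hydrogen on a saturated ring carbon), turning piperazin-1-yl into 3-methylpiperazin-1-yl. Among the compounds with values here, no measured pair shows what this change does in this assay, so the expectation starts from compound 2 at 43 ug/mL. A step within the scatter is expected, leaning slightly towards stronger inhibition. The expected step is a 1.2-fold lower number from compound 2 to compound 3 (0.09 log units; within the scatter). For compound 3 the estimated value is 35 ug/mL, with an expected range of 15 ug/mL to 80 ug/mL.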

Compound 3, half-maximal inhibitory concentration: 45 ug/mL
Compound 3: the middle estimate sits 1.3-fold (0.11 log units) below what was measured, within the range that was stated.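

In this assay the change from piperazin-1-yl to 3-methylpiperazin-1-yl comes to a 1.0-fold higher number from compound 2 to compound 3 (0.02 log units; within the scatter). Going by these compounds alone, this is the first measured pair for this change, and it shows that one methyl on a saturated ring carbon next to the ring nitrogen does not separate the two compounds on this read-out, a result that holds only for this pair. Nothing measured here bears on why the two compounds read alike.

The compounds shown leave open whether a longer chain such as ethyl or propyl on this ring carbon, or a second methyl there, would also stay within the scatter of compound 2. They also leave open how a hydroxyl or an amine on this carbon would read in this assay.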